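Ethoxy in place of iodo on the shared core

A few compounds are considered here, and "the series" means these few. Any claim that something is new, unique, unknown or untested is made for them only; others in the source may bear on it.

For the measured compounds named here, in a functional assay on HepG2 cells (Homo sapiens) for cytotoxicity, read by MTT assay (on this read-out higher numbers stand for weaker inhibition and lower numbers for stronger inhibition), compound 2 `C=C1C(=O)[C@]23C[C@@]1(I)CC[C@H]2[C@@]12C=CC(=O)[C@](C)(C(=O)O1)[C@H]2[C@@H]3C(=O)OC` gives 87000 nM, the highest of the two numbers so far, and compound 1 `C=C1C(=O)[C@]23C[C@@]1(O)CC[C@H]2[C@@]12C=CC(=O)[C@](C)(C(=O)O1)[C@H]2[C@@H]3C(=O)OC` gives 37200 nM. Compound 3 `C=C1C(=O)[C@]23C[C@@]1(OCC)CC[C@H]2[C@@]12C=CC(=O)[C@](C)(C(=O)O1)[C@H]2[C@@H]3C(=O)OC` carries ethoxy in place of iodo on a saturated ring carbon. Going by the values given here, one measured step bears on this carbon: a 2.3-fold higher number from compound 1 to compound 2 (0.37 log units; beyond the scatter), with iodo in place of hydroxy, modest and beyond the scatter. Ethoxy, like hydroxy, brings oxygen to that carbon, so a modest move back towards a lower number is expected. The expected change is a 1.9-fold lower number from compound 2 to compound 3 (0.29 log units; within the scatter). For compound 3 the estimated value is 45000 nM, with an expected range of 18000 nM to 100000 nM.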

Compound 3, half-maximal inhibitory concentration: 120000 nM
The estimate for compound 3 lay 2.7-fold (0.43 log units) below the measured number; measured number outside the range, above it.
By their numbers in this assay, from the lowest: compound 1; then compounds 2 and 3 (each within the scatter of the next).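

Oxygen on this saturated ring carbon is not enough to hold the number down: ethyl in place of hydrogen on that oxygen gives a 3.2-fold higher number from compound 1 to compound 3 (0.51 log units; beyond the scatter) as a modest step. Ethoxy in place of iodo gives a 1.4-fold higher number from compound 2 to compound 3 (0.14 log units; within the scatter) and so does not separate these two groups, leaving the hydroxy of compound 1 alone apart from the other two. No supporting data on hand account for this result. Going by these compounds, whether an amine or a methoxy on this carbon would fall with hydroxy or with iodo and ethoxy stays open.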